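Adding a Sulfo Group to Compound 3

The source may report more compounds than this note shows. Statements on the series, on what has been measured and on what is new or still open speak of the compounds shown alone.

In a functional assay on HCT-116 cells (Homo sapiens) for antiproliferative activity, with a stated time of 4 h (a higher number here means a weaker inhibitor, a lower number a stronger inhibitor), compound 1 `O=C1CCc2c1c1c(c3c2[nH]c2ccccc23)C(=O)NC1=O` gives 9700 nM and compound 2 `O=C1NC(=O)c2c1c1c(O)ccc(O)c1c1[nH]c3ccccc3c21` gives 3100 nM while compound 3 `Cc1ccc2[nH]c3c4c(O)ccc(O)c4c4c(c3c2c1)C(=O)NC4=O` gives 1600 nM as its result. Compound 3 sits at the low end of these numbers together with compound 2, and compound 1 lies clearly higher.

Compound 4 `Cc1ccc2[nH]c3c4c(OS(=O)(=O)O)ccc(O)c4c4c(c3c2c1)C(=O)NC4=O` has sulfo in place of hydrogen on an oxygen on an aromatic ring, so a hydroxy becomes a sulfooxy. Going by the values given here, the one measured step between close relatives (a 1.9-fold lower number from compound 2 to compound 3 (0.29 log units; within the scatter)) is methyl in place of hydrogen on an aromatic carbon, and it stays within the scatter. Among the compounds with values here, that is a different change, and no measured compound carries a sulfo group, so the guidance is thin. The sulfo swap is the larger change, so in this assay a moderate rise in the number, meaning a weaker inhibitor, is expected, with an estimated step (a 3.8-fold higher number from compound 3 to compound 4 (0.57 log units; beyond the scatter)) that remains uncertain. For compound 4 the estimated value is 6000 nM within a range of 1600 nM to 25000 nM on this limited evidence.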

Compound 4, half-maximal inhibitory concentration: > 40000 nM
Compound 4 was reported as a limit (the forecaster's own chance of this, stated with the estimate: 15%); at least 6.6-fold (0.82 log units) between middle value and limit.
By their numbers in this assay, from the lowest: compounds 3 and 2 (each within the scatter of the next); then compound 1. At a limit, above all of these: compound 4.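

Going by these compounds alone, the only earlier step between close relatives was a methyl on an aromatic carbon, which stayed within the scatter, so the oxygen had not yet been tested. In this assay, within the data shown here, turning this hydroxy into a sulfooxy gives an at least 25-fold higher number from compound 3 to compound 4 (1.39 log units; beyond the scatter), the first step that is clearly beyond the scatter and large, and it shows that this oxygen does not accept a sulfo group without a heavy loss of activity. The result for compound 4 is a limit and not an exact number: the limit of > 40000 nM in this assay, at which 1 of the 4 values shown sits.

As far as these compounds go, it remains open whether the loss comes from the hydrogen leaving this oxygen or from the sulfo group entering, and a methyl or an acetyl on the same oxygen would help separate the two. From the compounds shown here alone, it is also open whether the other hydroxy would respond in the same way.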